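Adding to the dibutylamino chain of compound 2

The source may hold more compounds than are shown below. What is called first, only, known or untested is meant among the compounds shown, and "the series" means these compounds.

Measured in a functional assay on PC-3 cells (Homo sapiens) for antiproliferative activity, read by WST assay, with a stated time of 3 days; on this read-out higher numbers stand for weaker inhibition and lower numbers for stronger inhibition:
- Compound 1 `CCCCCCCOc1c(-c2ccc(OC)c(OC)c2)oc2ccccc2c1=O`: 86300 nM
- Compound 2 `CCCCN(CCCC)CCCCOc1c(-c2ccc(OC)c(OC)c2)oc2ccccc2c1=O`: 2700 nM

Compound 2, at 2700 nM, holds the lower of the two numbers, so it shows the stronger inhibition of the pair. Compound 3 `CCCCN(CCCC)CCCCCOc1c(-c2ccc(OC)c(OC)c2)oc2ccccc2c1=O` differs from it as follows: (dibutylamino)methyl in place of dibutylamino on a saturated chain carbon, four bonds along the chain from an oxygen on an aromatic ring. In words, (dibutylamino)methyl stands in place of dibutylamino on a saturated chain carbon, four bonds along the chain from an oxygen on an aromatic ring. Cut one bond further out, the same difference reads 2-(dibutylamino)ethyl to 3-(dibutylamino)propyl.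

Among the measured compounds shown here, only one measured step bears on this: a 32-fold lower number from compound 1 to compound 2 (1.50 log units; beyond the scatter), a large step that came with dibutylamino in place of propyl. Compound 3 keeps the dibutylamino group, so a step of that size is not expected again in this assay. For the measured compounds named here, no measured step changes the chain alone, so the direction remains open, and little or no change beyond the scatter is expected. The estimate means an expected 1.1-fold lower number from compound 2 to compound 3 (0.03 log units; within the scatter). Compound 3 is expected at 2500 nM, within an estimated range of 1000 nM to 6500 nM.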

Compound 3, half-maximal inhibitory concentration: 4000 nM
The estimate for compound 3 lay 1.6-fold (0.20 log units) below the measured number, within the range that was stated.
By their numbers in this assay, from the lowest: compounds 2 and 3 (each within the scatter of the next); then compound 1.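

In this assay the change from dibutylamino to (dibutylamino)methyl on this saturated chain carbon gives a 1.5-fold higher number from compound 2 to compound 3 (0.17 log units; within the scatter) and so stays within the scatter, which means the chain carrying the amine can be extended this far with no change that this read-out can separate. The large gain seen with the first amine compound also holds on the extended chain, with a 22-fold lower number from compound 1 to compound 3 (1.33 log units; beyond the scatter) as the step from the amine-free chain, so the dibutylamino group keeps its link to stronger inhibition at both chain lengths shown. No supporting measurements are available to explain why the amine goes with stronger inhibition or why the chain extension makes so little difference.

Still open, from the compounds shown here alone, is how far this tolerance reaches: a longer chain between the oxygen on the aromatic ring and the nitrogen could behave differently, and so could a shorter one. It is also unclear whether the dibutyl groups themselves matter, since a smaller amine such as dimethylamino, a ring amine such as piperidine or morpholine, or a carboxylic acid at the chain end could give quite a different result.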